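Removing the Sugar from a Glycosylated Depside

A few compounds are considered here, and "the series" means these few. Any claim that something is new, unique, unknown or untested is made for them only; others in the source may bear on it.

Measured so far in a functional assay on BC cells (Homo sapiens) for cytotoxicity, read by colorimetric assay; a lower number here means a stronger inhibitor, a higher number a weaker inhibitor:
Compound 1, `CCCCCCCc1cc(O)cc(OC(=O)c2c(CCCCCCC)cc(O)cc2O[C@@H]2O[C@H](CO)[C@H](O)[C@H](O)[C@H]2O)c1`: 4400 nM
Compound 2, `CCCCCCCc1cc(O)cc(OC(=O)c2c(CCCCCCC)cc(O)cc2O[C@@H]2O[C@H](CO[C@@H]3O[C@H](CO)[C@H](O)[C@H](O)[C@H]3O)[C@H](O)[C@H](O)[C@H]2O)c1`: 20200 nM

Compound 1 holds the lowest of the two numbers; its nearest neighbour is compound 2, reached by a 4.6-fold higher number from compound 1 to compound 2 (0.66 log units; beyond the scatter). Compound 3, `CCCCCCCc1cc(O)cc(OC(=O)c2c(O)cc(O)cc2CCCCCCC)c1`, differs from compound 1 by hydrogen in place of 3,4,5-trihydroxy-6-(hydroxymethyl)oxan-2-yl on an oxygen on an aromatic ring. Within the data shown here, only the step from compound 1 to compound 2 bears on this change, and it runs the other way, adding sugar and weakening. Removing sugar is therefore expected to move this assay downward or leave it near compound 1. For compound 3 the expected step is a 2.2-fold lower number from compound 1 to compound 3 (0.34 log units; beyond the scatter), giving an estimate of 2000 nM within 700 nM to 6000 nM.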

Compound 3, half-maximal inhibitory concentration: 8800 nM
Compound 3: the middle estimate sits 4.4-fold (0.64 log units) below what was measured; the measured number lies above the stated range.
By their numbers in this assay, from the lowest: compounds 1 and 3 (each within the scatter of the next); then compound 2.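

In this assay, replacing the 3,4,5-trihydroxy-6-(hydroxymethyl)oxan-2-yl on the oxygen on the aromatic ring with hydrogen gives a 2.0-fold higher number from compound 1 to compound 3 (0.30 log units; within the scatter), so this sugar and the free hydroxy cannot be told apart here. The weakening seen when a sugar was added on an oxygen on a saturated carbon therefore does not carry over to this position. No available evidence explains the difference between the two places. The compounds shown leave open whether a methyl or a 2-aminoethyl group on this oxygen would also stay within the scatter of compound 1.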